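From 4-fluorobenzyl to 4-chlorobenzyl

The source may hold more compounds than are shown below. What is called first, only, known or untested is meant among the compounds shown, and "the series" means these compounds.

In a functional assay on RS4-11 cells (Homo sapiens) for inhibition, read by CCK-8 assay, with a stated time of 48 h, tested at 20 uM (a lower number here means less inhibition of growth, a higher number more inhibition of growth at the concentration tested), compound 1 `Cc1ccc(S(=O)(=O)Oc2ccccc2/C=C(\C#N)C(=O)Nc2nnc(Cc3cccc4ccccc34)s2)cc1` gives 73% and compound 2 `Cc1ccc(S(=O)(=O)Oc2ccccc2/C=C(\C#N)C(=O)Nc2nnc(Cc3ccc(F)cc3)s2)cc1` gives 72%, so compound 2 stands within the scatter of compound 1. Compound 3 `Cc1ccc(S(=O)(=O)Oc2ccccc2/C=C(\C#N)C(=O)Nc2nnc(Cc3ccc(Cl)cc3)s2)cc1` carries chloro in place of fluoro on an aromatic carbon, para to a large group: chloro in place of fluoro on an aromatic carbon. Among the compounds with values here, the only measured step bearing on this is a number 1 percentage points lower from compound 1 to compound 2 (within the scatter), which replaces naphthalen-1-yl with 4-fluorophenyl and stays within the scatter. No step beyond the scatter is therefore expected in this assay. The estimated step is no change at the digits printed from compound 2 to compound 3 (within the scatter). The expected value for compound 3 is 72%, with an estimated range of 62% to 82%.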

Compound 3, percent growth inhibition at one concentration: 69%
Compound 3: the middle estimate sits 3 percentage points above what was measured, within the range that was stated.
By their numbers in this assay, from the lowest: compounds 3, 2 and 1 (each within the scatter of the next).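

In this assay chloro in place of fluoro on the aromatic carbon para to a large group gives a number 3 percentage points lower from compound 2 to compound 3 (within the scatter) and so this place has now carried two different halogens with no step beyond the scatter. Set against naphthalen-1-yl, 4-chlorophenyl gives a number 4 percentage points lower from compound 1 to compound 3 (within the scatter) and all three groups thus stand within the scatter of one another. No measurement at hand offers an explanation for these steps.

Going by these compounds, whether an amine or a carboxylic acid at this aromatic carbon would move growth inhibition beyond the scatter stays open. So does the effect of a longer chain at the saturated carbon.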